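Acyl group swap on the shared amide core

The source may hold more compounds than are shown below. What is called first, only, known or untested is meant among the compounds shown, and "the series" means these compounds.

Going by the values given here, compound 3 `O=C(NCc1cccc(Cn2cnc3ccccc32)c1)c1nc2ccccc2[nH]1` gives 407 nM in an assay for inhibition of Indoleamine 2,3-dioxygenase 1 (Homo sapiens), read by HPLC, with a stated time of 48 h (a higher number here means a weaker inhibitor, a lower number a stronger inhibitor), the second highest of the three numbers measured so far. Compound 1 `O=C(NCc1cccc(Cn2cnc3ccccc32)c1)c1cc(Br)c[nH]1` gives 16 nM and compound 2 `O=C(NCc1cccc(Cn2cnc3ccccc32)c1)c1cc2cc(O)ccc2[nH]1` gives 781 nM; the step of a 1.9-fold lower number from compound 2 to compound 3 (0.28 log units; within the scatter) lies within the scatter, whereas a 25-fold higher number from compound 1 to compound 3 (1.41 log units; beyond the scatter) is large. Compound 4 `Cc1ccc(C(=O)NCc2cccc(Cn3cnc4ccccc43)c2)cc1` differs from compound 3 by 4-methylphenyl in place of 1H-benzimidazol-2-yl on a carbonyl carbon. Among the compounds with values here, the steps that bear on this change are a 25-fold higher number from compound 1 to compound 3 (1.41 log units; beyond the scatter) and a 49-fold higher number from compound 1 to compound 2 (1.69 log units; beyond the scatter), both exchanges of the group on the carbonyl carbon and both large, though nothing measured shows a phenyl-type group in this position. A step of moderate size in the weaker direction, not excluding none beyond the scatter, is expected: a 3.7-fold higher number from compound 3 to compound 4 (0.57 log units; beyond the scatter). For compound 4 the estimate in this assay is 1500 nM, ranging from 300 nM to 8000 nM.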

Compound 4, half-maximal inhibitory concentration: 327 nM
The estimate for compound 4 lay 4.6-fold (0.66 log units) above the measured number; the measured number falls inside the stated range.
By their numbers in this assay, from the lowest: compound 1; then compounds 4, 3 and 2 (each within the scatter of the next, the first and the last beyond it).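

In this assay, 4-methylphenyl on the carbonyl carbon carries neither the nitrogens nor the hydrogen-bond donor of 1H-benzimidazol-2-yl, yet the step stays within the scatter: a 1.2-fold lower number from compound 3 to compound 4 (0.10 log units; within the scatter). The gaps to the other two groups remain readable, with a modest step, a 2.4-fold lower number from compound 2 to compound 4 (0.38 log units; beyond the scatter), and a large one, a 20-fold higher number from compound 1 to compound 4 (1.31 log units; beyond the scatter), so 4-bromo-1H-pyrrol-2-yl still stands apart from the other three groups. Nothing available accounts for these steps. Open, on these data alone, is whether 4-bromophenyl or unsubstituted 1H-pyrrol-2-yl on the carbonyl carbon would give a number near that of compound 1 or near that of compound 4.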